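The compounds below may be only part of what the source reports. "The series", "measured", "known", "first", "only" and "open" are said of these compounds alone.

Of the compounds shown here, three have so far been measured in an assay on isolated protein for inhibition of DNA topoisomerase 1 (Homo sapiens), with a stated time of 30 min, tested at 20 uM; on this read-out lower numbers stand for a weaker effect and higher numbers for a stronger effect at the one concentration tested. Compound 1, `Oc1ccc(-c2cc(-c3cccs3)cc(-c3ccccc3O)n2)cc1`, gives 2%. Compound 2, `Oc1ccc(-c2cc(-c3cccs3)cc(-c3cccc(O)c3)n2)cc1`, differs from compound 1 in one place: 3-hydroxyphenyl in place of 2-hydroxyphenyl on an aromatic carbon. In this assay compound 2 gives 1.1%, so the step of a number 0.9 percentage points lower from compound 1 to compound 2 (within the scatter). Compound 3, `Oc1ccccc1-c1cc(-c2ccco2)cc(-c2ccccc2O)n1`, gives 0.2% in this assay; the difference between its core and that of compound 1 is not broken down here, and its value and that of compound 2 lie within the scatter of each other, as do its value and that of compound 1.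

Compound 4, `Oc1cccc(-c2cc(-c3ccco3)cc(-c3ccccc3O)n2)c1`, is not yet measured. It stands to compound 3 as compound 2 stands to compound 1: 3-hydroxyphenyl in place of 2-hydroxyphenyl on an aromatic carbon. The surroundings of the place differ, though: in compound 1 the changed group is meta to a 4-hydroxyphenyl group and meta to a thiophen-2-yl group, while in compound 3 it is meta to a 2-hydroxyphenyl group and meta to a furan-2-yl group, so this is the same kind of change, not the same change. Because the step of a number 0.9 percentage points lower from compound 1 to compound 2 (within the scatter) stayed within the scatter, compound 4 is expected to show a step of a number 0.3 percentage points higher from compound 3 to compound 4 (within the scatter) of similar size beside it. Compound 4 is estimated at 0.5%, between -3% and 4%.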

Compound 4, a percentage reported as inhibition, at one concentration (the size of the read-out at that concentration, not a potency): 0%
Compound 4: middle estimate off by 0.5 percentage points, on the high side, within the range that was stated.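

In this assay, putting 3-hydroxyphenyl in place of 2-hydroxyphenyl gives a number 0.2 percentage points lower from compound 3 to compound 4 (within the scatter), and set beside the earlier case, the change looks alike on the two cores: the same change on two cores in this assay, a number 0.9 percentage points lower (within the scatter) from compound 1 to compound 2 and a number 0.2 percentage points lower (within the scatter) from compound 3 to compound 4, 0.7 percentage points apart, within the scatter of two such steps So within this small set, the change can be carried from the core of compound 1 to the core of compound 3 without a readable difference in its outcome. This does not show that it would carry to every core, since both steps start from very small read-outs, 2% for compound 1 and 0.2% for compound 3, and a change that leaves such low numbers within the scatter says little about what it would do on a compound with a clear effect.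

Going by these compounds, it remains open whether an amine or a carboxylic acid on that phenyl ring, in place of the hydroxyl, would give a clearer read-out. Also open, on these data alone, is how these compounds would compare at other concentrations, as a single tested concentration gives no potency.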